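Bromo for methoxy on the shared core

The source may hold more compounds than are shown below. What is called first, only, known or untested is meant among the compounds shown, and "the series" means these compounds.

The series shares the core of compound 1 `CC(=O)/N=C1\NC2(CCCCO2)CCS1`, which in a functional assay on the whole organism (strain CF-1) with Mus musculus as the target, in the writhing test, with a stated time of 15 min (a higher number here means that more compound is needed for the effect, a lower number that less compound is needed), gives 3.1 mg/kg. Compound 2 `COc1ccc(C(=O)/N=C2\NC3(CCCCO3)CCS2)cc1` gives 62 mg/kg in this assay. Among the measured compounds shown here, on the two numbers in hand compound 2 stands highest; its value lies well beyond the scatter from that of compound 1, the only other compound measured.

Compound 3 `O=C(/N=C1\NC2(CCCCO2)CCS1)c1ccc(Br)cc1` is the next compound for this assay. Relative to compound 2 the change is bromo in place of methoxy on an aromatic carbon. For the measured compounds named here, no step of this kind has been measured, so the expectation rests only on compound 2 as the point of departure. The six-membered aromatic ring of carbon only and the carbonyl link to the core are unchanged, and the expected step is small, in either direction, not beyond the scatter: a 1.2-fold lower number from compound 2 to compound 3 (0.09 log units; within the scatter). Compound 3 is therefore estimated at 50 mg/kg in this assay, within a range from 18 mg/kg to 140 mg/kg.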

Compound 3, dose for half-maximal effect: > 200 mg/kg
Compound 3 was reported as a limit; the forecaster's own chance of this, stated with the estimate: 10%; middle value at least 4.0-fold (0.60 log units) from the limit.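

In this assay the result for compound 3 is a limit of the assay and not a number: the limit of > 200 mg/kg in this assay, at which 1 of the 3 values shown sits. Even so, the group on this aromatic carbon, para to a large group, is not interchangeable: bromo in place of methoxy gives an at least 3.2-fold higher number from compound 2 to compound 3 (0.50 log units; beyond the scatter), the first measured step at this position, and it lies beyond the scatter. The step from the methyl on the carbonyl carbon to 4-bromophenyl gives an at least 64-fold higher number from compound 1 to compound 3 (1.80 log units; beyond the scatter), so the loss seen with the aromatic ring of compound 2 depends on the group it carries.

As far as these compounds go, the true size of both steps stays open, since compound 3 has only a limit. Also open, from the compounds shown here alone, is whether an amine or a carboxylic acid on this aromatic carbon would bring the number closer to that of compound 1.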